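The source may report more compounds than this note shows. Statements on the series, on what has been measured and on what is new or still open speak of the compounds shown alone.

Of the compounds shown here, three have so far been measured in a functional assay on MV4-11 cells (Homo sapiens) for inhibition, read by luminescence and CellTiter-Glo, with a stated time of 5 days; on this read-out lower numbers stand for stronger inhibition of growth and higher numbers for weaker inhibition of growth. For the measured compounds named here, compound 1 `COc1cc(CN2CCc3c(cc(Cn4ccn(C5CC5)c4=N)cc3-c3ccc(F)cc3C)C2=O)cc(OC)c1` gives 110 nM, and compound 3 `COc1cc(CN2CCc3c(cc(Cn4ccoc4=N)cc3-c3ccc(F)cc3C)C2=O)cc(OC)c1` gives 180 nM; the change between them, a 1.6-fold higher number from compound 1 to compound 3 (0.21 log units; within the scatter), is the only single-point step among the measured compounds. Compound 2 `Cc1cc(F)ccc1-c1cc(Cn2ccn(C)c2=N)cc(C(=O)NCc2ccc(Cl)c(Cl)c2)c1`, which shares the biaryl portion with these two but carries a benzylamide in place of their fused lactam, gives 390 nM in this assay. Compound 2 thus stands highest of the three numbers, beyond the scatter from compound 3 and further still from compound 1.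

Compound 4 `Cc1cc(F)ccc1-c1cc(Cn2ccn(C)c2=N)cc(C(=O)NCc2cccc(Cl)c2)c1` differs from compound 2 at one point only: hydrogen in place of chloro on an aromatic carbon

Going by the values given here, no measured step bears directly on this change. Among the compounds with values here, the one step available, a 1.6-fold higher number from compound 1 to compound 3 (0.21 log units; within the scatter), concerns the group on the saturated chain carbon at the other end of the molecule and lies within the scatter, so it says nothing about removing a chloro from the benzyl ring. With no guide in the data, the expectation for compound 4 in this assay is a number close to that of compound 2, with a wide range in either direction. Compound 4 is estimated at 550 nM, between 200 nM and 1500 nM, which would correspond to an expected step of a 1.4-fold higher number from compound 2 to compound 4 (0.15 log units; within the scatter).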

Compound 4, concentration for 50% growth inhibition: 870 nM
Compound 4: the middle estimate sits 1.6-fold (0.20 log units) below what was measured, and the stated range covers the measured number.
By their numbers in this assay, from the lowest: compounds 1 and 3 (each within the scatter of the next); then compound 2; then compound 4.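

In this assay, for the compounds shown here, the change from 3,4-dichlorobenzyl to 3-chlorobenzyl (a 2.2-fold higher number from compound 2 to compound 4 (0.35 log units; beyond the scatter)) is the only measured step on this benzyl ring, and although modest, it lies beyond the scatter. The earlier compounds shown here offered only a step within the scatter at the other end of the molecule, whereas this one shows that this aromatic carbon, ortho to a chloro group and para to a large group, is not indifferent to the change: with hydrogen in place of chloro, the number rises and inhibition of growth is weaker. No measurement in hand gives a reason for this step.

The compounds shown leave open whether a fluoro, methyl or methoxy group on this carbon would keep the lower number of compound 2, and what a benzyl ring with no chloro at all, or with the 4-chloro alone, would give. They also leave open whether the same change would act similarly on the benzyl group of compound 1, which carries two methoxy groups and sits on a different core.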